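The source may hold more compounds than are shown below. What is called first, only, known or untested is meant among the compounds shown, and "the series" means these compounds.

Compound 1 `Nc1ncnc2c1c(-c1cnc3[nH]ccc3c1)nn2CC(=O)NO` and compound 2 `Nc1ncnc2c1c(-c1cnc3[nH]ccc3c1)nn2CCCCC(=O)NO` share one core, and compound 3 `Nc1nc2cc(-c3nn(CCCCCC(=O)NO)c4ncnc(N)c34)ccc2o1` together with the not yet measured compound 4 `Nc1nc2cc(-c3nn(CCCCCCCCC(=O)NO)c4ncnc(N)c34)ccc2o1` shares another; how the two cores differ is not broken down here. All four belong to the same series followed in a functional assay on MCF7 cells (Homo sapiens) for inhibition, read by MTT assay, with a stated time of 72 h; a higher number here means a weaker inhibitor, a lower number a stronger inhibitor. For compound 1 the result is a limit of the assay, > 150000 nM. For compound 2 the result is again a limit, > 150000 nM. Compound 3, by contrast, gives a number, 12400 nM.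

Between compound 1 and compound 2 the change is 3-(hydroxycarbamoyl)propyl in place of hydroxycarbamoyl on a saturated chain carbon bound to an aromatic nitrogen. The size of that step is a step that the two limits leave unreadable from compound 1 to compound 2; it cannot be read because of the limit of > 150000 nM in this assay, at which 2 of the 3 values shown sit. The change from compound 3 to compound 4 is 3-(hydroxycarbamoyl)propyl in place of hydroxycarbamoyl on a saturated chain carbon, five bonds along the chain from an aromatic nitrogen. It is the same kind of change, but the place differs: in compound 1 the chain carbon carrying the group is bound to an aromatic nitrogen, while in compound 3 it sits five bonds along the chain from an aromatic nitrogen.

For compound 4 the step in this assay is expected to be a 1.2-fold higher number from compound 3 to compound 4 (0.08 log units; within the scatter), resting only on the number of compound 3, 12400 nM, as the earlier pair gives no readable size to lean on. Compound 4 is therefore estimated at 15000 nM, somewhere between 4000 nM and 60000 nM.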

Compound 4, half-maximal inhibitory concentration: 42100 nM
Compound 4: the middle estimate sits 2.8-fold (0.45 log units) below what was measured; the measured number falls inside the stated range.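

In this assay, on the core shared by compound 3 and compound 4, putting 3-(hydroxycarbamoyl)propyl in place of hydroxycarbamoyl at that place on the chain gives a 3.4-fold higher number from compound 3 to compound 4 (0.53 log units; beyond the scatter), so the longer chain reads as a modestly weaker inhibitor on this core. The same kind of change on the other core, from compound 1 to compound 2, cannot be read, because both of those results are limits of the assay and not numbers: the limit of > 150000 nM in this assay, at which 2 of the 4 values shown sit. The series therefore gives a size for this change on one core only, and it does not show whether the change carries over to the other core, in either size or direction, particularly as the change also sits at a different place along the chain there.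

The compounds shown leave open whether a still longer chain on the core of compound 3 would keep raising the number, and whether (hydroxycarbamoyl)methyl on that core would give a readable value to set against compound 1. They also leave open how a carboxylic acid or an amine in place of hydroxycarbamoyl would read on either core.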